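The source may report more compounds than this note shows. Statements on the series, on what has been measured and on what is new or still open speak of the compounds shown alone.

Measured so far in a functional assay on HT-1080 cells (Homo sapiens) for antiproliferative activity, read by MTT assay, with a stated time of 72 h; on this read-out higher numbers stand for weaker inhibition and lower numbers for stronger inhibition:

- compound 1 `CCOC(=O)c1cc(-c2cc(OC)c(OC)c(OC)c2)c(-c2ccc(OC)c([N+](=O)[O-])c2)s1` gives 12700 nM
- compound 2 `CCOC(=O)c1cc(-c2cc(OC)c(OC)c(OC)c2)c(-c2ccc3ccccc3c2)s1` gives 1150 nM

Of these two numbers, compound 1 has the higher, which makes it the weaker inhibitor of the pair. Among the measured compounds shown here, the only measured step, an 11-fold lower number from compound 1 to compound 2 (1.04 log units; beyond the scatter), is large and comes from naphthalen-2-yl in place of 4-methoxy-3-nitrophenyl on an aromatic carbon.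

The next compound, compound 3 `COc1ccc(-c2sc(C(=O)O)cc2-c2cc(OC)c(OC)c(OC)c2)cc1[N+](=O)[O-]`, keeps the 4-methoxy-3-nitrophenyl group and differs from compound 1 elsewhere: hydrogen in place of ethyl on an oxygen next to a carbonyl group. This is hydrogen in place of ethyl on an oxygen next to a carbonyl group, so ethoxycarbonyl becomes carboxy.

The measured step lies at a different place and bears on this change only indirectly. It shows that one change can move the numbers in this assay a long way, but it gives neither the size nor the direction of this one. For the measured compounds named here, no measured pair covers ethoxycarbonyl to carboxy, so the expectation is a judgement: a moderate move to a higher number, held loosely. The expected step is a 2.2-fold higher number from compound 1 to compound 3 (0.34 log units; beyond the scatter). For compound 3 the estimated value is 28000 nM, with an expected range from 9000 nM to 90000 nM.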

Compound 3, half-maximal inhibitory concentration: 37200 nM
Beside the measured number, compound 3's estimate is 1.3-fold (0.12 log units) below it; the measured number falls inside the stated range.
By their numbers in this assay, from the lowest: compound 2; then compound 1; then compound 3.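

Replacing the ethyl with hydrogen on an oxygen next to a carbonyl group, which turns ethoxycarbonyl into carboxy, gives a 2.9-fold higher number from compound 1 to compound 3 (0.47 log units; beyond the scatter) in this assay. Among the compounds shown here, until now both compounds carried the ethoxycarbonyl group, so this is the first sign that this position affects the read-out, and here the ester gives the stronger inhibition of the two, though the step is modest rather than large. Nothing available explains why removing the ethyl weakens inhibition.

From the compounds shown here alone, this single pair was read only with the 4-methoxy-3-nitrophenyl group in place, so it remains open whether the same loss would appear in a carboxy partner of compound 2, which carries naphthalen-2-yl instead. The compounds shown also leave open how this position would respond to other groups, such as a methyl ester, an ester with a longer chain, or a primary amide, and so whether the ethyl itself matters or any ester would serve equally well.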